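A few compounds are considered here, and "the series" means these few. Any claim that something is new, unique, unknown or untested is made for them only; others in the source may bear on it.

Measured compounds:
compound 1, `COc1ncnc2c1c(-c1ccsc1)cn2[C@@H]1O[C@H](CO)[C@@H](O)[C@H]1O`: 3350 nM
compound 2, `CSc1ncnc2c1c(-c1ccccc1)cn2[C@@H]1O[C@H](CO)[C@@H](O)[C@H]1O`: > 20000 nM
compound 3, `COc1nc(N)nc2c1c(-c1ccccc1)cn2[C@@H]1O[C@H](CO)[C@@H](O)[C@H]1O`: > 20000 nM

Compound 3 stands at the edge of the numbers shown. In a functional assay on HeLa S3 cells (Homo sapiens) for antiproliferative activity, read by XTT assay, with a stated time of 72 h (on this read-out higher numbers stand for weaker inhibition and lower numbers for stronger inhibition), compound 3 returns only a limit, > 20000 nM, not a number. Compound 2 likewise returns only a limit in this assay, > 20000 nM. For the measured compounds named here, compound 1 is the one member of the set with a measured number in this assay, 3350 nM. Two of the three results thus sit at the same boundary, as shown by the limit of > 20000 nM in this assay, at which 2 of the 3 values shown sit, and no step between measured compounds can be set out.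

Compound 4, `COc1ncnc2c1c(-c1ccccc1)cn2[C@@H]1O[C@H](CO)[C@@H](O)[C@H]1O`, arises from compound 3 by the change (hydrogen in place of amino on an aromatic carbon), that is, the amino leaves and a hydrogen enters on that aromatic carbon. In this assay the step is expected to run toward stronger inhibition and to exceed the scatter, though from a limit its size cannot be fixed. Compound 4 is estimated at 4000 nM, within 1000 nM to 20000 nM, meaning a step of an at least 5.0-fold lower number from compound 3 to compound 4 (0.69 log units; beyond the scatter). This expectation rests on compound 1, whose value of 3350 nM comes from the closest measured analogue of compound 4.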

Compound 4, half-maximal inhibitory concentration: > 20000 nM
Compound 4: a limit, no number; the forecaster's own chance of this, stated with the estimate: 25%; at least 5.0-fold (0.69 log units) between middle value and limit.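

In this assay, phenyl in place of thiophen-3-yl on the aromatic carbon gives an at least 5.9-fold higher number from compound 1 to compound 4 (0.77 log units; beyond the scatter), so among the compounds shown, only compound 1, with its thiophen-3-yl, returns a measured number. Compound 4, with hydrogen in place of amino, returns only a limit, > 20000 nM, so this change on the aromatic carbon between two ring nitrogen atoms yields no measured number. The steps to compound 4 from compound 2 and from compound 3 cannot be read, and the set now gathers at one boundary: the limit of > 20000 nM in this assay, at which 3 of the 4 values shown sit.

On these data alone, how far compound 2, compound 3 and compound 4 lie beyond that limit stays open, and with it any difference among methoxy, methylsulfanyl and amino. Also open, as far as these compounds go, is whether furan-3-yl in the place of thiophen-3-yl, or a dimethylamino group in the place of methoxy, would return a measured number.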